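The source may report more compounds than this note shows. Statements on the series, on what has been measured and on what is new or still open speak of the compounds shown alone.

Compound 1, `CCc1cc(C(C)=O)c(O)cc1OCCCCCCC#N` — in an assay on isolated protein for binding affinity to leukotriene B4 receptor 1 (Homo sapiens), tested at 1 uM (a higher number here means more inhibition at the concentration tested (going by the name of the read-out), a lower number less inhibition), compound 1 gives 73%.
Compound 2, `CCc1cc(C(C)=O)c(O)cc1OCCCCCCC(=O)O` — in this assay compound 2 gives 38%.

For the measured compounds named here, compound 2 stands at the lower of the two numbers so far; the only measured step is a number 35 percentage points lower from compound 1 to compound 2 (beyond the scatter), a large drop when the carboxy group replaces the cyano group at the end of the chain. Compound 3, `CCc1cc(C(C)=O)c(O)cc1OCCCCCn1cncn1`, continues from compound 2 by 1H-1,2,4-triazol-1-yl in place of carboxymethyl on a saturated chain carbon, five bonds along the chain from an oxygen on an aromatic ring. This step bears only loosely on the measured one: the carboxy group that accompanied the drop leaves again, while a five-membered aromatic ring takes its place, a kind of group not seen in either measured compound. Given that compound 1, without a carboxy group, gave 73%, the inhibition is expected to rise again, with an estimated step of a number 22 percentage points higher from compound 2 to compound 3 (beyond the scatter). Compound 3 is therefore estimated at 60%, within a range from 30% to 85%.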

Compound 3, a percentage reported as inhibition, at one concentration (the size of the read-out at that concentration, not a potency): 30%
For compound 3 the middle estimate is 30 percentage points above the measured one, and the stated range covers the measured number.
By their numbers in this assay, from the lowest: compounds 3 and 2 (each within the scatter of the next); then compound 1.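

In this assay, for the compounds shown here, the chain end carries a ring for the first time, and the result is a number 8 percentage points lower from compound 2 to compound 3 (within the scatter) so 1H-1,2,4-triazol-1-yl and the carboxy-ended chain cannot be told apart here. Set against the nitrile, the same ring gives a number 43 percentage points lower from compound 1 to compound 3 (beyond the scatter) so removing the carboxy group does not by itself restore the level of compound 1, and of these three end groups only the nitrile stands clear of the others. Nothing available explains why these end groups give these results.

From the compounds shown here alone, whether an amine or a primary amide at the chain end would sit with compound 1 or with compound 2 and compound 3 stays open. So does whether a longer chain carrying the same 1H-1,2,4-triazol-1-yl would change the picture.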